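Replacing a methoxyphenyl with a thiourea-like tail

This account rests on a few compounds, and the source may have more. Where it says the series, first, only, none or still open, it means among the compounds named here.

In a functional assay on L929 cells (Mus musculus) for inhibition (on this read-out higher numbers stand for weaker inhibition of growth and lower numbers for stronger inhibition of growth), compound 1, with structure `Nc1nn2c(O)cc(CCl)nc2c1[N+](=O)[O-]`, gives only a limit of > 50 ug/mL. Compound 2, with structure `COc1ccc(NNCc2cc(O)n3nc(N)c([N+](=O)[O-])c3n2)cc1`, likewise gives only a limit of > 50 ug/mL in this assay. So compound 2 stands at the edge of what this assay can report, as summarised by the limit of > 50 ug/mL in this assay, at which 2 of the 2 values shown sit. Compound 3, with structure `Nc1nn2c(O)cc(CNNC(N)S)nc2c1[N+](=O)[O-]`, differs from compound 2 by amino(sulfanyl)methyl in place of 4-methoxyphenyl on an amine nitrogen. Going by the values given here, no measured step between two compounds exists here, so nothing shows how large a change such a swap brings in this assay. Given that compound 2 reaches only > 50 ug/mL, the expected step from compound 2 to compound 3 is a number no higher from compound 2 to compound 3 (the limit leaves the size open), essentially none beyond the scatter. For compound 3 the estimated value is therefore 50 ug/mL, within the expected range of 20 ug/mL to 100 ug/mL.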

Compound 3, concentration for 50% growth inhibition: > 50 ug/mL
Compound 3 gave a limit, no number; the forecaster's own chance of this, stated with the estimate: 75%; the middle value sits exactly at the limit.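

Compound 3, like compound 1 and compound 2, gives only a limit in this assay, so the steps among them cannot be read: the limit of > 50 ug/mL in this assay, at which 3 of the 3 values shown sit. The compounds shown leave open how strongly any of them inhibits growth, and whether amino(sulfanyl)methyl in place of 4-methoxyphenyl changes anything.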